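The compounds below may be only part of what the source reports. "The series", "measured", "known", "first", "only" and "open" are said of these compounds alone.

Of the compounds shown here, two sharing one core have so far been measured in an assay on HEK293 cells for agonist activity at Toll-like receptor 8 (Homo sapiens), read by spectrophotometry; on this read-out lower numbers stand for an effect already at smaller amounts and higher numbers for an effect only at larger amounts of compound. Compound 1 `CCCCNc1nc(N)nc(C)c1CCCN1C(=O)c2ccccc2C1=O` gives 453 nM, and compound 2 `CCCCNc1nc(N)nc(C)c1CCCC(C)(C)O` gives 1220 nM. Compound 2 therefore stands at the higher of the two numbers; its nearest neighbour is compound 1, whose number is lower by a margin beyond the usual scatter of repeated measurements.

The next step leads from compound 2 to compound 3 `CCCCNc1nc(N)nc(C)c1CCCn1cncn1`, which has not yet been measured in this assay.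

1H-1,2,4-triazol-1-yl in place of 1-hydroxy-1-methylethyl on a saturated chain carbon, three bonds along the chain from an aromatic carbon

What leaves is the 1-hydroxy-1-methylethyl group, which carries a hydroxyl; what enters is the 1H-1,2,4-triazol-1-yl group, a small aromatic ring. For the measured compounds named here, no pair of measured compounds differing in a single place exists, so there is no directly comparable step to draw on. Going by the values given here, the only hint comes from compound 1, which carries a ring at the end of the same chain and, with 453 nM, sits below compound 2. On that thin basis compound 3 is expected to show a moderate step downward, a 2.0-fold lower number from compound 2 to compound 3 (0.31 log units; beyond the scatter), to an estimated 600 nM, somewhere between 250 nM and 1500 nM.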

Compound 3, half-maximal effective concentration: 1050 nM
The estimate for compound 3 lay 1.8-fold (0.24 log units) below the measured number; measured number inside the range.
By their numbers in this assay, from the lowest: compound 1; then compounds 3 and 2 (each within the scatter of the next).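

In this assay the exchange of the 1-hydroxy-1-methylethyl group for the 1H-1,2,4-triazol-1-yl group on this saturated chain carbon gives a 1.2-fold lower number from compound 2 to compound 3 (0.07 log units; within the scatter) and so leaves the two compounds indistinguishable, even though a group with a hydroxyl and no ring has given way to a five-membered aromatic ring with no hydrogen-bond donor. Compound 3 gives 1050 nM and compound 1 gives 453 nM so carrying a ring at the end of this chain is not enough on its own to reach the number of compound 1. Nothing available here explains why these two different groups give such similar numbers. Going by these compounds, it remains open whether an amine or a carboxylic acid at the end of the chain would move the number beyond the scatter, and whether a longer chain carrying the 1H-1,2,4-triazol-1-yl group would do so. On these data alone, it also remains open whether another ring in the same place, such as a phenyl or an imidazole, would behave like the 1H-1,2,4-triazol-1-yl group.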